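A ring replaced by an open chain on the shared core

The source may report more compounds than this note shows. Statements on the series, on what has been measured and on what is new or still open speak of the compounds shown alone.

compound 1 `c1ccc(-c2cnoc2)c(NCC2=NCCN2)c1` — < 100000 nM
compound 2 `Nc1nccc(-c2ccccc2NCC2=NCCN2)n1` — 28.8 nM
compound 3 `FC(F)(F)c1cccnc1-c1ccccc1NCC1=NCCN1` — < 100000 nM

In a functional assay for activation of Alpha-1D adrenergic receptor (Homo sapiens) (a higher number here means that more compound is needed for the effect, a lower number that less compound is needed), the value for compound 1 is a limit of the assay and not a number, < 100000 nM. Compound 3 also reaches only a limit in this assay, < 100000 nM. Compound 2 gives a number in this assay, 28.8 nM. Compound 1 therefore stands at the limit of < 100000 nM in this assay, at which 2 of the 3 values shown sit.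

Compound 4 `CC/C(=N/OC)c1ccccc1NCC1=NCCN1` differs from compound 1 by a group of 6 heavy atoms (4 carbon, 1 nitrogen, 1 oxygen; no ring) in place of a group of 5 heavy atoms (3 carbon, 1 nitrogen, 1 oxygen; one five-membered aromatic ring with 2 hetero atoms), on an aromatic carbon. Within the data shown here, no measured pair differs in this one place, so the size of this change in this assay cannot be read from the data. The expected step that the limit leaves unreadable from compound 1 to compound 4 is small, not beyond the usual scatter, with a fair chance that compound 4 again yields only a limit. For compound 4 the estimated value in this assay is 40000 nM, in the range 3000 nM to 100000 nM.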

Compound 4, half-maximal effective concentration: < 5020 nM
Compound 4: only a limit was reported; the forecaster's own chance of this, stated with the estimate: 50%; middle value at least 7.9-fold (0.90 log units) away from the limit.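

Among these compounds, compound 1 and compound 4 both give only limits of the assay, so no step between them can be read. The compounds shown leave open how far the 1,2-oxazol-4-yl ring and the open chain differ in effect.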